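The source may hold more compounds than are shown below. What is called first, only, known or untested is meant among the compounds shown, and "the series" means these compounds.

Measured compounds:
Compound 1 `CCN(CC)CCCOc1cc2ncnc(Nc3ccc(C#N)cc3)c2cc1OC`: in a functional assay on MCF7 cells (Homo sapiens) for antiproliferative activity, read by MTT assay, with a stated time of 72 h (on this read-out higher numbers stand for weaker inhibition and lower numbers for stronger inhibition), compound 1 gives > 100000 nM, which is a limit of the assay and not a number.
Compound 2 `COc1cc2c(Nc3ccc(C#N)cc3)ncnc2cc1OCCCN1CCCCC1CCO`: in this assay compound 2 gives > 100000 nM, again a limit rather than a number.

Compound 1 therefore stands at the ceiling of this assay, with no measured number of its own. Among the compounds with values here, its one measured neighbour, compound 2, sits at the same ceiling, so the step that the two limits leave unreadable from compound 1 to compound 2 cannot be read in either direction. What is known of this pair is summed up by the limit of > 100000 nM in this assay, at which 2 of the 2 values shown sit.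

Compound 3 `COc1cc2c(Nc3ccc(C#N)cc3)ncnc2cc1OCCCN1CCN(c2ccncc2)CC1` differs from compound 1 in one place: 4-(pyridin-4-yl)piperazin-1-yl in place of diethylamino on a saturated chain carbon, three bonds along the chain from an oxygen on an aromatic ring. Within the data shown here, the only measured step that touches this position on the chain is a step that the two limits leave unreadable from compound 1 to compound 2, and its size is not readable. The two values give no sign that a swap at this saturated chain carbon moves the read-out off the limit. Compound 3 is thus expected to stay near the ceiling, with an expected step that the limit leaves unreadable from compound 1 to compound 3. Compound 3 is estimated at 150000 nM, with a range from 30000 nM to 800000 nM, and most likely the assay again reports only a limit.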

Compound 3, half-maximal inhibitory concentration: 22900 nM
Beside the measured number, compound 3's estimate is 6.6-fold (0.82 log units) above it, and the stated range ends above it.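

In this assay the saturated chain carbon, three bonds along the chain from an oxygen on an aromatic ring, proves able to move the read-out: 4-(pyridin-4-yl)piperazin-1-yl in place of diethylamino gives an at least 4.3-fold lower number from compound 1 to compound 3 (0.64 log units; beyond the scatter) and, in place of 2-(2-hydroxyethyl)piperidin-1-yl, it gives an at least 4.3-fold lower number from compound 2 to compound 3 (0.64 log units; beyond the scatter) in the same direction. Compound 3 is the first compound shown with a number of its own, and it shares the core of compound 1 and differs from it in this one place. Both steps are only lower bounds, and their full size stays unknown because the other two compounds rest on a limit: the limit of > 100000 nM in this assay, at which 2 of the 3 values shown sit.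

The compounds shown do not tell whether the step belongs to the piperazine part of the new group or to the pyridin-4-yl part carried on it. Going by these compounds, a 4-methylpiperazin-1-yl or a 4-phenylpiperazin-1-yl group on the same chain would separate the two, and it also remains open how a longer chain between the oxygen and the piperazine would read out.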